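Replacing the Thiadiazole of Compound 2 with a Phenylthiazole

The source may hold more compounds than are shown below. What is called first, only, known or untested is meant among the compounds shown, and "the series" means these compounds.

Measured in a functional assay on HepG2 cells (Homo sapiens) for inhibition, read by MTT assay, with a stated time of 48 h; on this read-out lower numbers stand for stronger inhibition and higher numbers for weaker inhibition:
Compound 1 `CCOC(=O)C1=C(N/C=N/c2cccnc2Cl)Nc2[nH]nc(C)c2C1c1ccc(N(C)C)cc1`: 4890 nM
Compound 2 `CCOC(=O)C1=C(N/C=N/c2nnc(S(N)(=O)=O)s2)Nc2[nH]nc(C)c2C1c1ccc(N(C)C)cc1`: 38100 nM

In this assay compound 2 has the higher number of the two, 38100 nM, and so the weaker inhibition. Compound 3 `CCOC(=O)C1=C(N/C=N/c2ncc(-c3ccccc3)s2)Nc2[nH]nc(C)c2C1c1ccc(N(C)C)cc1` has not yet been measured. It carries 5-phenyl-1,3-thiazol-2-yl in place of 5-sulfamoyl-1,3,4-thiadiazol-2-yl on a double-bonded nitrogen. Going by the values given here, the only measured step at this place is a 7.8-fold higher number from compound 1 to compound 2 (0.89 log units; beyond the scatter), modest but beyond the scatter, with 5-sulfamoyl-1,3,4-thiadiazol-2-yl in place of 2-chloropyridin-3-yl. Compound 3 loses that same group, so a step toward a lower number is expected, similar in size or smaller, though one step is thin support. The expected change is a 4.2-fold lower number from compound 2 to compound 3 (0.63 log units; beyond the scatter). Compound 3 is estimated at 9000 nM, with an expected range of 2500 nM to 30000 nM.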

Compound 3, half-maximal inhibitory concentration: 9790 nM
Compound 3: the middle estimate sits 1.1-fold (0.04 log units) below what was measured; low and high end bracket the measured number.
By their numbers in this assay, from the lowest: compounds 1 and 3 (each within the scatter of the next); then compound 2.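

In this assay the exchange of 5-sulfamoyl-1,3,4-thiadiazol-2-yl for 5-phenyl-1,3-thiazol-2-yl gives a 3.9-fold lower number from compound 2 to compound 3 (0.59 log units; beyond the scatter) and so shows a second group on the double-bonded nitrogen that stands apart from compound 2. Set against 2-chloropyridin-3-yl, the same group gives a 2.0-fold higher number from compound 1 to compound 3 (0.30 log units; within the scatter) and so cannot be told apart from it here, although it brings a second aromatic ring, one of carbon only. No measured evidence is at hand to explain either step.

On these data alone, what a bare 1,3-thiazol-2-yl, or a phenyl carrying an amine or a carboxylic acid, would do on this nitrogen stays open. So does whether a sulfamoyl group added to the phenyl of compound 3 would bring the number back toward that of compound 2.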